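The compounds below may be only part of what the source reports. "The series", "measured", "known", "first", "only" and "open" are said of these compounds alone.

Measured compounds:
Compound 1 `Cc1ccccc1C(=O)NCc1ccc(CNS(=O)(=O)c2ccccc2C)cc1` gives 10 nM in an assay on MDA-MB-231 cells for displacement of a labelled ligand from C-X-C chemokine receptor type 4 (Homo sapiens), read by fluorescence and microscopy, with stated times of 10 min and 30 min; a higher number here means that more compound is needed for the effect, a lower number that less compound is needed.
Compound 2 `Cc1cccc(S(=O)(=O)NCc2ccc(CNC(=O)c3cccnc3)cc2)c1` gives 10 nM in this assay.
Compound 3 `O=C(NCc1ccc(CNS(=O)(=O)c2ccc(Cl)cc2)cc1)c1cccnc1` gives 1000 nM in this assay.

Compound 1 stands level with compound 2 at the digits shown, and together they sit at the lowest of the three numbers; compound 3 lies a full a 100-fold higher number from compound 2 to compound 3 (2.00 log units; beyond the scatter) away from compound 2, a step well beyond the scatter, and the same distance separates compound 1 from compound 3.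

Compound 4 `Cc1ccccc1C(=O)NCc1ccc(CNS(=O)(=O)c2ccccc2Cl)cc1` has not yet been measured. It differs from compound 1 by chloro in place of methyl on an aromatic carbon. Among the measured compounds shown here, only one measured step bears on this: a 100-fold higher number from compound 2 to compound 3 (2.00 log units; beyond the scatter), where 4-chlorophenyl replaced 3-methylphenyl on a sulfonyl sulfur. That step, however, moved the group around the ring as well as swapping methyl for chloro, so it does not isolate the change in hand. It shows that a chloro for methyl exchange on this ring can cost a great deal; whether the same holds with the group kept at its own place is not known from the data. A moderate increase is therefore expected, a 4.0-fold higher number from compound 1 to compound 4 (0.60 log units; beyond the scatter), with a wide range. Compound 4 is estimated at 40 nM, between 8 nM and 400 nM.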

Compound 4, effective concentration (reported as EC, without a stated level of effect): 1000 nM
Compound 4: middle estimate off by 25-fold (1.40 log units), on the low side; the whole stated range lies below it.
By their numbers in this assay, from the lowest: compounds 1 and 2 (each within the scatter of the next); then compounds 3 and 4 (each within the scatter of the next).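

With the group kept at its own place, on an aromatic carbon ortho to a large group, chloro in place of methyl gives a 100-fold higher number from compound 1 to compound 4 (2.00 log units; beyond the scatter) in this assay. This separates the exchange from any move around the ring, which the earlier step, a 100-fold higher number from compound 2 to compound 3 (2.00 log units; beyond the scatter), could not do: going from 2-methylphenyl to 2-chlorophenyl is enough on its own for a large step, although the two groups match in the heavy-atom, donor and acceptor counts. Nothing in the available data accounts for this loss.

On these data alone, it remains open whether the same exchange would cost as much at another place on this ring, or on the core of compound 1 with its other end changed. As far as these compounds go, it is also open whether a fluoro group, a methoxy group or an amine at this same place would stay level with compound 1 at 10 nM or rise as far as compound 4 at 1000 nM.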